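A few compounds are considered here, and "the series" means these few. Any claim that something is new, unique, unknown or untested is made for them only; others in the source may bear on it.

Compound 1, `NC(=O)Cn1c(-c2ccc(C(F)(F)F)cc2)nc2cccnc21`, in a functional assay on the whole organism with Mus musculus as the target; a lower number here means that less compound is needed, a higher number that more compound is needed for the effect: 11.7 mg/kg
Compound 2, `CN(C)C(=O)Cn1c(-c2ccc(Br)o2)nc2cccnc21`: 100 mg/kg
Compound 3, `CNC(=O)Cn1c(-c2ccc(Cl)cc2)nc2cccnc21`: 12.5 mg/kg

All three compounds share the same core and differ in the amide end of the side chain and in the aromatic group attached to the core. Compound 3 stands second highest of the three doses. Its nearest neighbour is compound 1, whose dose is lower by a margin within the usual scatter of repeated measurements, so the two cannot be told apart. Farthest away is compound 2, whose dose is higher by a margin beyond that scatter.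

Compound 4, `CCOC(=O)CCCNC(=O)Cn1c(-c2ccc(Cl)cc2)nc2cccnc21`, has not yet been measured in this assay. It differs from compound 3 in one place: 2-(ethoxycarbonyl)ethyl in place of hydrogen on a saturated chain carbon bound to an amide-type nitrogen. Cut one bond further out, the same difference reads methyl to 3-(ethoxycarbonyl)propyl, or methylamino to (3-(ethoxycarbonyl)propyl)amino.

Among the compounds with values here, no pair of measured compounds differs in only one place, so there is no direct precedent for a change of this kind. Compound 2 and compound 3 differ at the amide but also in the aromatic group, so their values show only that the set spans a wide range. A small rise in dose is expected, a 1.6-fold higher number from compound 3 to compound 4 (0.20 log units; within the scatter), though the direction is uncertain. Compound 4 is estimated at 20 mg/kg, with a likely range from 8 mg/kg to 60 mg/kg.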

Compound 4, dose for half-maximal effect: 100 mg/kg
Compound 4: the middle estimate sits 5.0-fold (0.70 log units) below what was measured; measured number above the stated range.
By their numbers in this assay, from the lowest: compounds 1 and 3 (each within the scatter of the next); then compounds 2 and 4 (each within the scatter of the next).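

Within the data shown here, compound 3 and compound 4 give the first comparison in this set that differs in one place only, so the chain on the amide nitrogen can be judged apart from the aromatic group. In this assay, putting 2-(ethoxycarbonyl)ethyl in place of hydrogen on the saturated chain carbon bound to the amide-type nitrogen gives an 8.0-fold higher number from compound 3 to compound 4 (0.90 log units; beyond the scatter), a step beyond the usual scatter, which shows that this position does not accept every change without a cost in dose. Nothing shown here says why the dose rises.

Open, going by these compounds, is whether the ester end of the chain or the chain itself carries this step, which a plain propyl chain, the carboxylic acid or an amine at the end of the chain would help to separate. Also open, on these data alone, is whether the step holds with another aromatic group on the shared core, such as the trifluoromethyl-bearing one of compound 1.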